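The source may report more compounds than this note shows. Statements on the series, on what has been measured and on what is new or still open speak of the compounds shown alone.

The series rests on a shared core, carried by compound 1 `Cc1ccccc1-c1ccc(CCC(=O)N2CCCC2)cc1` and compound 2 `O=C(CCc1ccc(-c2ccc(Cl)cc2)cc1)N1CCCC1`. In an assay on HEK293 cells for inhibition of N-acylethanolamine-hydrolyzing acid amidase (Rattus norvegicus), read by LC-MS, with a stated time of 30 min (on this read-out lower numbers stand for stronger inhibition and higher numbers for weaker inhibition), compound 1 gives only a limit, > 100000 nM. In this assay compound 2 gives 48600 nM. Going by the values given here, the one measured step, an at least 2.0-fold lower number from compound 1 to compound 2 (0.31 log units; beyond the scatter), is bounded by the limit of > 100000 nM in this assay, at which 1 of the 2 values shown sits, and so sets no firm size. Among the numbers shown, compound 2 therefore holds the only true number in this assay, the remaining value being a limit.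

Compound 3 `O=C(CCc1ccc(Oc2ccccc2)cc1)N1CCCC1` arises from compound 2 through (phenoxy in place of 4-chlorophenyl on an aromatic carbon). Among the compounds with values here, no measured step exchanges a phenoxy for a 4-chlorophenyl, so the step from compound 1 to compound 2 bears on it only by showing how little the series has moved so far. A step in this assay of no more than modest size is therefore expected, with a weaker number somewhat more likely than a stronger one, and a fair chance that only a limit is returned. Compound 3 is accordingly estimated at 65000 nM in this assay, between 15000 nM and 250000 nM, which means an expected step of a 1.3-fold higher number from compound 2 to compound 3 (0.13 log units; within the scatter).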

Compound 3, half-maximal inhibitory concentration: > 100000 nM
Compound 3: a limit, no number; the forecaster's own chance of this, stated with the estimate: 35%; at least 1.5-fold (0.18 log units) between middle value and limit.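

At the aromatic carbon para to a group of 9 heavy atoms, the result shows that this place does not tolerate every ring-bearing group equally: in this assay, phenoxy in place of 4-chlorophenyl gives an at least 2.0-fold higher number from compound 2 to compound 3 (0.31 log units; beyond the scatter), a step whose true size the limit leaves unfixed. The two groups match in heavy atoms and each carries one six-membered aromatic ring of carbon only, so an exchange that swaps chlorine for oxygen and adds one hydrogen-bond acceptor is enough to return the series to a limit, although the data do not say which of these differences matters. The step from compound 1 to compound 3 joins two limits and cannot be read, and compound 2 remains the only compound with a true number: the limit of > 100000 nM in this assay, at which 2 of the 3 values shown sit.

On these data alone, how far compound 3 lies beyond compound 2 stays open, as does whether any group at this place can bring the number much lower than compound 2 does. As far as these compounds go, whether a benzyloxy group or a carboxylic acid here would give a true number in this assay also remains open, and so does the effect of a longer chain between the ring and the carbonyl.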